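Swapping an Amino Group for a Piperidinyl Ester Side Chain

The compounds below may be only part of what the source reports. "The series", "measured", "known", "first", "only" and "open" are said of these compounds alone.

Values in an ADME assay on L6 cells (Rattus norvegicus) for cytotoxicity, read by resazurin assay, with a stated time of 72 h; on this read-out lower numbers stand for stronger inhibition and higher numbers for weaker inhibition:
- Compound 1 `O=C(CN1CCCCC1)OC1CC2(N3CCCC3)CC(c3ccccc3)C1C(c1ccccc1)C2`: 14200 nM
- Compound 2 `NC1CC2(N3CCCCC3)CC(c3ccccc3)C1C(c1ccccc1)C2`: 35000 nM

Compound 2 stands highest of the two at 35000 nM, meaning weaker inhibition, and its gap to compound 1 lies beyond the scatter. Compound 3 `O=C(CN1CCCCC1)OC1CC2(N3CCCCC3)CC(c3ccccc3)C1C(c1ccccc1)C2` keeps the core of compound 2 and changes a single group: (((piperidin-1-yl)methyl)carbonyl)oxy in place of amino on a saturated ring carbon. Within the data shown here, no measured pair shows this change on its own. Still, compound 1 carries the same entering group and gives 14200 nM, so a lower number is expected in this assay. The expected size is an estimated 2.5-fold lower number from compound 2 to compound 3 (0.40 log units; beyond the scatter). The estimate for compound 3 is 14000 nM, with an expected range from 6000 nM to 32000 nM.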

Compound 3, half-maximal inhibitory concentration: 60400 nM
Estimate against measurement, compound 3: 4.3-fold (0.63 log units) below; measured number above the stated range.
By their numbers in this assay, from the lowest: compound 1; then compounds 2 and 3 (each within the scatter of the next).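

In this assay the (((piperidin-1-yl)methyl)carbonyl)oxy group in place of amino on this saturated ring carbon gives a 1.7-fold higher number from compound 2 to compound 3 (0.24 log units; within the scatter), so this much larger group and amino cannot be told apart when the core carries piperidin-1-yl. With the ester side chain kept, piperidin-1-yl in place of pyrrolidin-1-yl gives a 4.3-fold higher number from compound 1 to compound 3 (0.63 log units; beyond the scatter), so the lower number of compound 1 goes with its pyrrolidin-1-yl group. Nothing available explains either step.

Open, from the compounds shown here alone, is how a hydroxyl group or a longer chain at this carbon would read, and whether amino on the pyrrolidin-1-yl core would match compound 1.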